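The source may report more compounds than this note shows. Statements on the series, on what has been measured and on what is new or still open speak of the compounds shown alone.

In a functional assay on ACHN cells (Homo sapiens) for antiproliferative activity, read by sulforhodamine B assay (a lower number here means a stronger inhibitor of growth, a higher number a weaker inhibitor of growth), compound 1, `COc1cccc(OCCC(C)(C)C)c1C(=O)/C=C/c1ccc(O)cc1`, gives only a limit, > 30000 nM, which marks the edge of the measurement rather than a number. Of the two values shown, one sits at the limit of > 30000 nM in this assay, at which 1 of the 2 values shown sits. For the measured compounds named here, compound 2, `O=C(/C=C/c1ccc(O)cc1)c1c(O)cccc1OCCC1CCCC1`, gives 3400 nM in this assay, and this is the only actual number in the set, so compound 2 stands alone as the one measured point of reference. Compound 3, `CCC(CC)COc1cccc(O)c1C(=O)/C=C/c1ccc(O)cc1`, differs from compound 2 by pentan-3-yl in place of cyclopentylmethyl on a saturated chain carbon bound to an oxygen on an aromatic ring. Going by the values given here, no measured pair differs in one place only, so no step of known size is available as a guide. The group that leaves and the group that enters are alike in kind, both carbon only with no donors or acceptors, so in this assay the step of a 1.3-fold higher number from compound 2 to compound 3 (0.12 log units; within the scatter) is expected to stay within the usual scatter. Compound 3 is therefore expected to give about 4500 nM in this assay, most likely between 1500 nM and 15000 nM.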

Compound 3, concentration for 50% growth inhibition: 3370 nM
Compound 3: middle estimate off by 1.3-fold (0.13 log units), on the high side, and the stated range covers the measured number.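

In this assay, pentan-3-yl in place of cyclopentylmethyl on a saturated chain carbon bound to an oxygen on an aromatic ring gives a 1.0-fold lower number from compound 2 to compound 3 (0.00 log units; within the scatter). For the compounds shown here, this is the first measured step at this position, and it shows that in this pair the five-membered ring is not needed to keep the activity: a group with no ring serves equally well. Nothing measured here gives a reason for this match.

On these data alone, only groups of carbon alone appear at this position, so it remains open how an amine, a carboxylic acid or a longer chain would fare there in this assay. As far as these compounds go, compound 1 gives only a limit, > 30000 nM, and it differs from compound 2 and compound 3 in more than one place, so what sets it apart also stays open.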